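Turning one stereocentre in a fluorinated pair

A few compounds are considered here, and "the series" means these few. Any claim that something is new, unique, unknown or untested is made for them only; others in the source may bear on it.

In a functional assay on Vero cells (Chlorocebus sabaeus) for inhibition (a higher number here means a weaker inhibitor, a lower number a stronger inhibitor), compound 1 (`Nc1ccn([C@H]2O[C@@H](CO)C=C2F)c(=O)n1`) gives > 100000 nM as its result, which is a limit. Compound 2 (`Nc1ccn([C@@H]2O[C@@H](CO)C=C2F)c(=O)n1`) gives > 100000 nM as its result, also a limit. Compound 3 (`Nc1nc(=O)n([C@@H]2O[C@@H](CO)C=C2F)cc1F`) gives > 100000 nM as its result, again a limit and not a number. It therefore stands with the others, as shown by the limit of > 100000 nM in this assay, at which 3 of the 3 values shown sit, and no compound here has a true value.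

Compound 4 (`Nc1nc(=O)n([C@H]2O[C@@H](CO)C=C2F)cc1F`) changes compound 3 in one way: the two compounds have the same atoms and bonds and differ only in configuration as drawn: 1 of 2 stereo elements differ; a stereocentre at a saturated ring carbon is drawn R in compound 3 and S in compound 4. For the measured compounds named here, the closest precedent is a step that the two limits leave unreadable from compound 1 to compound 2, the same kind of change, as the fact that compounds 1 and 2 differ only in the configuration as drawn makes clear. The other measured change is a step that the two limits leave unreadable from compound 2 to compound 3, so neither offers a size to carry over. No step beyond the scatter is therefore expected in this assay, and no direction is favoured. The estimated step is a number no higher from compound 3 to compound 4 (the limit leaves the size open) in this reading. Compound 4 is expected to give about 100000 nM, with an estimated range from 40000 nM to 200000 nM and a limit again the likeliest report.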

Compound 4, half-maximal inhibitory concentration: > 100000 nM
Compound 4 gave a limit, no number; the forecaster's own chance of this, stated with the estimate: 85%; the middle value lies on the limit itself.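

In this assay compound 4 gives > 100000 nM, a limit and not a number. The steps from compound 3 to compound 4 and from compound 1 to compound 4 cannot be read, with limits on both sides. As far as these compounds go, whether turning this stereocentre or adding the fluoro changes inhibition at all stays open: none of the four compounds has a true value.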